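The compounds below may be only part of what the source reports. "The series", "measured", "known", "first", "only" and "open" are said of these compounds alone.

Working notes on the series. Compound 1 `CC1CCN(c2c(S(=O)(=O)c3ccc(F)cc3)cnc3ccc(F)cc23)CC1` gives 87% in an assay on isolated protein for displacement of a labelled ligand from metabotropic glutamate receptor 5 (Homo sapiens), with a stated time of 60 min, tested at 1 uM (on this read-out higher numbers stand for more inhibition at the one concentration tested (going by the name of the read-out) and lower numbers for less inhibition), and compound 2 `CC1CCN(c2c(S(=O)(=O)c3ccc(Cl)c(Cl)c3)cnc3ccc(F)cc23)CC1` gives 91%; compound 2 stands highest of the two, with the step of a number 4 percentage points higher from compound 1 to compound 2 (within the scatter) lying within the scatter. Compound 3 `Cc1cc(C)cc(S(=O)(=O)c2cnc3ccc(F)cc3c2N2CCC(C)CC2)c1` differs from compound 2 by 3,5-dimethylphenyl in place of 3,4-dichlorophenyl on a sulfonyl sulfur. Going by the values given here, the only step that bears on the aryl group on the sulfonyl sulfur is a number 4 percentage points higher from compound 1 to compound 2 (within the scatter), which suggests that exchanging that aryl group leaves the read-out roughly unchanged. For compound 3 a step of a number 6 percentage points lower from compound 2 to compound 3 (within the scatter) is therefore expected, not beyond the scatter. Compound 3 is estimated at 85%, within 68% to 96%.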

Compound 3, a percentage reported as inhibition, at one concentration (the size of the read-out at that concentration, not a potency): 83%
The estimate for compound 3 lay 2 percentage points above the measured number, within the range that was stated.
By their numbers in this assay, from the lowest: compounds 3, 1 and 2 (each within the scatter of the next).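

In this assay, the step to 3,5-dimethylphenyl reads as a number 8 percentage points lower from compound 2 to compound 3 (within the scatter) and a number 4 percentage points lower from compound 1 to compound 3 (within the scatter). A third aryl group on the sulfonyl sulfur, and the first of the three with no halogen, therefore leaves the read-out within the scatter of both earlier groups, including against 3,4-dichlorophenyl with its equal heavy-atom count. No measurement on hand offers an explanation for this.

The compounds shown leave open whether an aryl group carrying an amine or a carboxylic acid, or a longer alkyl chain in place of the aryl group, would keep the read-out. With one concentration only, any potency differences among these three also stay open.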